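Replacing the ring group on the shared core

A few compounds are considered here, and "the series" means these few. Any claim that something is new, unique, unknown or untested is made for them only; others in the source may bear on it.

Among the measured compounds shown here, compound 3 `COc1cc(-c2cnn3cc(OC)c([C@H]4COC(C)(C)C4)nc23)ccn1` gives 4100 nM in an assay on isolated protein for inhibition of activin receptor type-2A (Homo sapiens), read by 33P incorporation, with a stated time of 20 min, in the presence of a further agent that is not named here (on this read-out lower numbers stand for stronger inhibition and higher numbers for weaker inhibition), the highest of the three numbers measured so far. Compound 1 `COc1cc(-c2cnn3cc(OC)c(-c4cc(C)no4)nc23)ccn1` gives 3000 nM in this assay, and compound 2 `COc1cc(-c2cnn3cc(OC)c(C)nc23)ccn1` gives 1200 nM. The gap a 1.4-fold higher number from compound 1 to compound 3 (0.14 log units; within the scatter) lies within the scatter, whereas a 3.4-fold higher number from compound 2 to compound 3 (0.53 log units; beyond the scatter) lies beyond it, as does a 2.5-fold lower number from compound 1 to compound 2 (0.40 log units; beyond the scatter).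

Compound 4 `COc1cc(-c2cnn3cc(OC)c(N(C)C)nc23)ccn1` differs from compound 3 by a group of 3 heavy atoms (2 carbon, 1 nitrogen; no ring) in place of a group of 7 heavy atoms (6 carbon, 1 oxygen; one five-membered non-aromatic ring with 1 hetero atom), on an aromatic carbon. The measured step that bears most directly on this change is a 3.4-fold higher number from compound 2 to compound 3 (0.53 log units; beyond the scatter), in which the same ring group entered in place of one carbon atom; compound 4 carries a group without a ring, smaller than the ring group it replaces. The step of a 2.5-fold lower number from compound 1 to compound 2 (0.40 log units; beyond the scatter) points in the same direction, a smaller group going with a lower number. For the measured compounds named here, for compound 4 a modest lower number in this assay is therefore expected, a 2.6-fold lower number from compound 3 to compound 4 (0.41 log units; beyond the scatter), though no measured compound carries a dimethylamino group. Compound 4 is estimated at 1600 nM, with a range of 600 nM to 4500 nM.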

Compound 4, half-maximal inhibitory concentration: 3000 nM
For compound 4 the middle estimate is 1.9-fold (0.27 log units) below the measured one; the measured number falls inside the stated range.
By their numbers in this assay, from the lowest: compound 2; then compounds 1, 4 and 3 (each within the scatter of the next).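

In this assay the dimethylamino group on this aromatic carbon, next to the ring nitrogen, does not separate from the larger groups: a 1.4-fold lower number from compound 3 to compound 4 (0.14 log units; within the scatter) and no change at the digits printed from compound 1 to compound 4 (within the scatter) both stay within the scatter. Methyl alone stands apart, the step to dimethylamino being a 2.5-fold higher number from compound 2 to compound 4 (0.40 log units; beyond the scatter) and so the earlier link between a smaller group and a lower number does not hold across the set, with compound 4 going against it: its group is small, yet its number is level with those of compound 1 and compound 3. Nothing at hand explains why methyl differs from the other three groups.

From the compounds shown here alone, whether the lower number belongs to methyl alone or extends to other small groups stays open; ethyl, cyclopropyl or methylamino on this carbon would test that. The compounds shown also keep the rest of the shared core fixed, so whether this order holds with other groups elsewhere on the core is open too.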